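The source may hold more compounds than are shown below. What is called first, only, known or untested is meant among the compounds shown, and "the series" means these compounds.

Working notes on the series. Going by the values given here, the shared core carries a substituent on the aromatic carbon of the five-membered ring that sits next to the ring nitrogen and the ring sulfur, and the three measured members differ only there. Compound 1 `COc1ccc(-c2nc(/N=C(\N)N(C)C)sc2-c2ccc(OC)cc2)cc1` gives 4.8 uM in a functional assay (aorta) with Rattus norvegicus as the target; on this read-out higher numbers stand for an effect only at larger amounts of compound and lower numbers for an effect already at smaller amounts. Compound 2 `COc1ccc(-c2nc(CN(C)C)sc2-c2ccc(OC)cc2)cc1` gives 8.4 uM in this assay, and compound 3 `COc1ccc(-c2nc(CNC(=O)c3cccnc3)sc2-c2ccc(OC)cc2)cc1` gives 8.2 uM. The steps are a 1.8-fold higher number from compound 1 to compound 2 (0.24 log units; within the scatter), a 1.7-fold higher number from compound 1 to compound 3 (0.23 log units; within the scatter) and a 1.0-fold lower number from compound 2 to compound 3 (0.01 log units; within the scatter), so compound 3 lies within the scatter of both other measured compounds and the three numbers cannot be ranked.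

Compound 4 `COc1ccc(-c2nc(C(=O)N3CCCCC3)sc2-c2ccc(OC)cc2)cc1` is not yet measured. It differs from compound 3 in one place: (piperidin-1-yl)carbonyl in place of (((pyridin-3-yl)carbonyl)amino)methyl on an aromatic carbon. Among the compounds with values here, no measured step installs a carbonyl directly on that aromatic carbon, so the change is not covered by a like-for-like precedent. What bears on it is that three quite different groups on this carbon, with and without a ring, with and without a hydrogen-bond donor, all land within the scatter of each other. The expectation is therefore no step beyond the scatter in this assay: the estimated step is a 1.2-fold lower number from compound 3 to compound 4 (0.07 log units; within the scatter). Compound 4 is estimated at 7 uM, with a range from 2.5 uM to 20 uM.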

Compound 4, concentration for half-maximal effect: 11 uM
The estimate for compound 4 lay 1.6-fold (0.20 log units) below the measured number, within the range that was stated.
By their numbers in this assay, from the lowest: compounds 1, 3, 2 and 4 (each within the scatter of the next, the first and the last beyond it).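

Going by these compounds alone, the (piperidin-1-yl)carbonyl group, with its carbonyl directly on the aromatic carbon, gives the first step at this position that lies beyond the scatter in this assay, though the step is modest and appears only against compound 1 (a 2.3-fold higher number from compound 1 to compound 4 (0.36 log units; beyond the scatter)). Against the two compounds that carry a saturated chain carbon on this position, the same group stays within the scatter (a 1.3-fold higher number from compound 3 to compound 4 (0.13 log units; within the scatter); a 1.3-fold higher number from compound 2 to compound 4 (0.12 log units; within the scatter)), so moving the carbonyl onto the aromatic carbon and losing the amide hydrogen of compound 3 produce no readable change here. No supporting data are available to explain why these groups differ so little or why only compound 1 and compound 4 separate.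

The compounds shown leave open whether any group on this carbon moves the number well beyond this narrow band, for example a carboxylic acid, a small primary amide or a longer chain ending in an amine. They also leave open how much this position matters compared with the two 4-methoxyphenyl groups, which are the same in all four compounds.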